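The source may report more compounds than this note shows. Statements on the series, on what has been measured and on what is new or still open speak of the compounds shown alone.

Measured so far:
- compound 1, `COc1ccc(-n2sc(=O)n(C3CCCCC3)c2=O)cc1`: 36300 nM
- compound 2, `O=c1sn(-c2ccc(F)cc2)c(=O)n1-c1ccccc1`: 13400 nM

In an ADME assay, in phosphate buffer, with a stated time of 30 min, tested at 1 mM, at a dose of 1 mM, in the presence of a further agent that is not named here (on this read-out lower numbers stand for lower exposure and higher numbers for higher exposure at the dose given), compound 1 gives 36300 nM, the higher of the two numbers. Compound 2 gives 13400 nM, and the gap between the two lies beyond the usual scatter of this measurement. Compound 3, `COc1ccc(-n2sc(=O)n(Cc3ccccc3)c2=O)cc1`, is not yet measured. It differs from compound 1 in one place: benzyl in place of cyclohexyl on an aromatic nitrogen. Among the compounds with values here, no measured pair shows this particular change, so its size is unknown; only a small step is expected, possibly none beyond the scatter, in either direction. For compound 3 the estimate in this assay is 27000 nM, with a range from 11000 nM to 65000 nM. That estimate amounts to an expected step of a 1.3-fold lower number from compound 1 to compound 3 (0.13 log units; within the scatter).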

Compound 3, maximal plasma concentration: 5910 nM
For compound 3 the middle estimate is 4.6-fold (0.66 log units) above the measured one; the whole stated range lies above it.
By their numbers in this assay, from the lowest: compound 3; then compound 2; then compound 1.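

In this assay, the group on this aromatic nitrogen clearly matters: benzyl in place of cyclohexyl gives a 6.1-fold lower number from compound 1 to compound 3 (0.79 log units; beyond the scatter) even though both groups carry a six-membered ring of carbon only. Having a ring of that size at this position is therefore not enough to keep the number high; which ring it is, and how it is attached, can go with much lower exposure. Nothing available explains this step.

Going by these compounds, it remains open how a longer chain or a benzyl carrying an amine would behave on this nitrogen. On these data alone, whether the same change gives a similar step on another core also remains open.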